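A few compounds are considered here, and "the series" means these few. Any claim that something is new, unique, unknown or untested is made for them only; others in the source may bear on it.

Measured in a functional assay on HT-29 cells (Homo sapiens) for antiproliferative activity, read by MTT assay, with a stated time of 72 h; a lower number here means a stronger inhibitor, a higher number a weaker inhibitor:
- Compound 1 `C=CC(=O)Nc1nc(-c2ccccc2)cs1`: 6600 nM
- Compound 2 `C=CC(=O)Nc1nc(-c2ccccc2OC)cs1`: > 30000 nM
- Compound 3 `C=CC(=O)Nc1nc(-c2ccccc2)c(C)s1`: 22000 nM

The entry for compound 2 is a limit of the assay and not a number. Of the two true numbers in this assay, compound 1 has the lower, and compound 3 is its nearest neighbour.

Compound 4 `C=CC(=O)N(CC(=O)O)c1nc(-c2ccccc2)cs1` keeps the core of compound 1 but differs by carboxymethyl in place of hydrogen on an amide-type nitrogen, which places carboxymethyl in place of hydrogen on an amide-type nitrogen. Two measured steps offer a guide: an at least 4.5-fold higher number from compound 1 to compound 2 (0.65 log units; beyond the scatter), with methoxy in place of hydrogen on an aromatic carbon, and a 3.3-fold higher number from compound 1 to compound 3 (0.52 log units; beyond the scatter), with methyl in place of hydrogen on an aromatic carbon. Both raised the number, but neither touches the amide-type nitrogen, so they bear on this change only loosely. Going by those two steps from compound 1, a similar rise is expected, of a 3.3-fold higher number from compound 1 to compound 4 (0.52 log units; beyond the scatter) in this assay. The estimate for compound 4 is 22000 nM, with an expected range from 8000 nM to 60000 nM.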

Compound 4, half-maximal inhibitory concentration: > 30000 nM
Compound 4: no number, only a limit; the forecaster's own chance of this, stated with the estimate: 40%; middle value at least 1.3-fold (0.13 log units) away from the limit.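

This is the first change shown on the amide-type nitrogen rather than on an aromatic carbon: in this assay, carboxymethyl in place of the amide hydrogen gives an at least 4.5-fold higher number from compound 1 to compound 4 (0.65 log units; beyond the scatter). Compound 1, with its amide hydrogen in place, therefore remains the stronger inhibitor, and this position does not accept carboxymethyl without a loss of activity. For compound 4, > 30000 nM is a limit of the assay and not a number, so the true size of the loss cannot be read, and the same limit caps more than one compound: the limit of > 30000 nM in this assay, at which 2 of the 4 values shown sit.

The compounds shown do not tell whether any group on this nitrogen raises the number or only carboxymethyl does. A small ethyl group, or the ethyl ester of the same chain, on this nitrogen would help to separate those two readings.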